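Swapping the aryl ketone: thiazolyl to pyridinyl

The source may hold more compounds than are shown below. What is called first, only, known or untested is meant among the compounds shown, and "the series" means these compounds.

Measured compounds:
compound 1, `Cc1ccc(C(=O)c2nc(N(C)Cc3cccnc3)nc3ccsc23)s1`, 4140 nM
compound 2, `Cc1ccc(C(=O)c2nc(NC(C)c3ccccn3)nc3ccsc23)s1`, 19 nM
compound 3, `O=C(c1cncs1)c1nc(NCc2cccnc2)nc2ccsc12`, 148 nM

Three compounds share a core and differ in the side groups. In a functional assay on CHO-K1 cells for antagonist activity at adenosine receptor A2b (Homo sapiens), read by FLIPR and calcium flux (a higher number here means a weaker inhibitor, a lower number a stronger inhibitor), compound 2 gives the lowest number, compound 1 the highest, and compound 3 stands second highest, separated from each neighbour by a gap beyond the scatter. Compound 4, `O=C(c1ccncc1)c1nc(NCc2cccnc2)nc2ccsc12`, carries pyridin-4-yl in place of 1,3-thiazol-5-yl on a carbonyl carbon. Going by the values given here, no measured pair shows this exact change, so its effect is unknown; the expected step of a 1.4-fold higher number from compound 3 to compound 4 (0.13 log units; within the scatter) is small, with little or no shift beyond the scatter. Compound 4 is therefore estimated at 200 nM, within a range of 60 nM to 700 nM.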

Compound 4, half-maximal inhibitory concentration: 869 nM
Estimate against measurement, compound 4: 4.3-fold (0.64 log units) below; measured number outside the range, above it.
By their numbers in this assay, from the lowest: compound 2; then compound 3; then compound 4; then compound 1.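

In this assay, the ring on the carbonyl carbon clearly matters: with everything else unchanged, pyridin-4-yl in place of 1,3-thiazol-5-yl gives a 5.9-fold higher number from compound 3 to compound 4 (0.77 log units; beyond the scatter). Going by these compounds alone, this is the first pair here that differs in only one place, so this position can now be read on its own. Nothing measured here explains the step. As far as these compounds go, whether a phenyl ring or pyridin-3-yl on the carbonyl would behave like pyridin-4-yl or 1,3-thiazol-5-yl stays open. So does whether the same step would appear with the amine side chain of compound 2.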